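Compound 3 to compound 4: a benzyl group at the limit

A few compounds are considered here, and "the series" means these few. Any claim that something is new, unique, unknown or untested is made for them only; others in the source may bear on it.

In an ADME assay on CHO cells (Cricetulus griseus) for inhibition, read by MTT assay (on this read-out higher numbers stand for weaker inhibition and lower numbers for stronger inhibition), compound 3 (`CCN(CC)Cc1cccc(Nc2nc3ccccc3[nH]2)c1O`) gives > 50000 nM as a limit and not a number. Compound 1 (`CCN(CC)Cc1cccc(Nc2nc3ccccc3n2Cc2ccc(C#N)cc2)c1O`) gives > 50000 nM as a limit too. Compound 2 (`CCN(CC)Cc1cccc(Nc2nc3ccccc3n2Cc2ccc(F)cc2)c1O`) gives > 50000 nM as a limit too. Compound 3 therefore offers no number to start from.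

Compound 4 (`CCN(CC)Cc1cccc(Nc2nc3ccccc3n2Cc2ccc(C(F)(F)F)cc2)c1O`) carries 4-(trifluoromethyl)benzyl in place of hydrogen on an aromatic nitrogen. The nearest evidence is the same kind of change in reverse: a step that the two limits leave unreadable from compound 1 to compound 3 and a step that the two limits leave unreadable from compound 2 to compound 3 each remove a substituted benzyl group. The remaining comparison is a step that the two limits leave unreadable from compound 1 to compound 2 and it exchanges the group on that benzyl. None of the three has a readable size, so none gives a direction. Compound 1 and compound 2 carry a substituted benzyl group there and sit at the limit of > 50000 nM in this assay, at which 3 of the 3 values shown sit, and no step beyond the scatter is therefore expected. The expected size is a step that the limit leaves unreadable from compound 3 to compound 4 by this estimate. A further report as a limit is the likeliest outcome. For compound 4 the estimate is 60000 nM with an expected range of 25000 nM to 150000 nM in this assay on the same read-out.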

Compound 4, half-maximal inhibitory concentration: > 50000 nM
Compound 4 was reported as a limit; the forecaster's own chance of this, stated with the estimate: 85%; the middle value lies beyond the limit too.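

Compound 4 is reported as a limit and not a number, like compound 1, compound 2 and compound 3, so no step among these four compounds can be read: the limit of > 50000 nM in this assay, at which 4 of the 4 values shown sit.

The compounds shown leave open whether any benzyl group shown, including 4-(trifluoromethyl)benzyl, changes inhibition at all on this read-out.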